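The compounds below may be only part of what the source reports. "The series", "measured", "known", "first", "only" and "open" are said of these compounds alone.

Compound 1 `CCCCNC(=S)N/N=C\c1c[nH]c2ccccc12` in an ADME assay on KB cells (Homo sapiens) for cytotoxicity, read by MTT assay, with a stated time of 44 h (a lower number here means a stronger inhibitor, a higher number a weaker inhibitor), gives > 100000 nM, which is a limit of the assay rather than a number.
Compound 2 `CCCNC(=S)N/N=C\c1c[nH]c2ccccc12` in this assay gives > 100000 nM, again a limit.
Compound 3 `CC(C)CNC(=S)N/N=C\c1c[nH]c2ccccc12` in this assay gives > 100000 nM, also a limit.

Compound 3 therefore stands at the same limit as the other two; the limit of > 100000 nM in this assay, at which 3 of the 3 values shown sit, is all the evidence there is. The steps a step that the two limits leave unreadable from compound 1 to compound 2, a step that the two limits leave unreadable from compound 1 to compound 3 and a step that the two limits leave unreadable from compound 2 to compound 3 are each unreadable, since both ends are limits. Compound 4 `S=C(NCc1ccccc1Cl)N/N=C\c1c[nH]c2ccccc12` differs from compound 3 by 2-chlorophenyl in place of isopropyl on a saturated chain carbon bound to an amide-type nitrogen. For the measured compounds named here, none of the measured steps touches a group of this kind, so no size or direction can be drawn from them. The step that the limit leaves unreadable from compound 3 to compound 4 is expected to be close to nothing, most likely still a limit. Compound 4 is estimated at 150000 nM, within 30000 nM to 1000000 nM.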

Compound 4, half-maximal inhibitory concentration: > 100000 nM
Compound 4: only a limit was reported (the forecaster's own chance of this, stated with the estimate: 70%); the middle value lies beyond the limit too.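

Compound 4 also sits at a limit in this assay, so its steps from compound 1, compound 2 and compound 3 cannot be read: the limit of > 100000 nM in this assay, at which 4 of the 4 values shown sit. On these data alone, whether these four compounds differ from one another at all remains open.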